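A few compounds are considered here, and "the series" means these few. Any claim that something is new, unique, unknown or untested is made for them only; others in the source may bear on it.

Three compounds have so far been measured in an assay on CHO cells for displacement of a labelled ligand from adenosine receptor A1 (Homo sapiens), read by scintillation counting, with a stated time of 60 min, tested at 10 uM; a higher number here means more inhibition at the concentration tested (going by the name of the read-out), a lower number less inhibition:

Compound 1, `COc1cccc2cc(C(=O)NCCO)c(=N)oc12`, gives 47%.
Compound 2, `COCCNC(=O)c1cc2cccc(OC)c2oc1=O`, gives 45%.
Compound 3, `COc1cccc2cc(C(=O)Nc3c(C#N)ncn3-c3ccccc3)c(=N)oc12`, gives 33%.

Among these three numbers compound 1 has the highest. Compound 2 comes out only slightly lower, and the gap between the two lies within the usual scatter of repeated measurements, so the two cannot be told apart on these numbers. Compound 3 sits further down, and that gap is beyond the scatter.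

The next compound, compound 4, `COc1cccc2cc(C(=O)NC3CCCCC3)c(=N)oc12`, has not yet been measured in this assay. It differs from compound 1 in one place: cyclohexyl in place of 2-hydroxyethyl on an amide-type nitrogen. Among the measured compounds shown here, none of the three measured compounds differ from one another in a single place, so there is no measured step that shows what such an exchange does; compound 2 and compound 3 each differ from compound 1 in more than one way at once.

With nothing to lean on, the expectation is cautious: a step from compound 1 to compound 4 of about a number 2 percentage points lower from compound 1 to compound 4 (within the scatter) is expected, that is, no change beyond the scatter. Compound 4 is therefore estimated to give 45%, with a range from 20% to 70%.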

Compound 4, a percentage reported as inhibition, at one concentration (the size of the read-out at that concentration, not a potency): 40%
For compound 4 the middle estimate is 5 percentage points above the measured one, within the range that was stated.
By their numbers in this assay, from the lowest: compounds 3, 4, 2 and 1 (each within the scatter of the next, the first and the last beyond it).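

Among the compounds shown here, this is the first change made at one place only, so the amide-type nitrogen can now be judged from a measured step rather than from compounds that differ in several ways at once. In this assay, cyclohexyl in place of 2-hydroxyethyl gives a number 7 percentage points lower from compound 1 to compound 4 (within the scatter) and so stays within the usual scatter, although the group that enters is a carbon-only ring of 6 heavy atoms with 0 hydrogen-bond donors and 0 hydrogen-bond acceptors, while the group that leaves has 3 heavy atoms, 1 hydrogen-bond donor and 1 hydrogen-bond acceptor. No supporting evidence is available to explain this result.

A single step cannot show whether other groups on this nitrogen would also stay within the scatter, such as a chain ending in an amine, a carboxylic acid or a longer carbon chain. It also leaves open whether the same exchange would give a similar result on a different core, and a reading at one concentration does not establish potency.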